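Phenoxymethyl in place of benzyl on a shared core

The compounds below may be only part of what the source reports. "The series", "measured", "known", "first", "only" and "open" are said of these compounds alone.

Compound 1: `CC(=O)c1cccc(N/C(=N/O)c2ccc3occc3c2)c1` gives > 30000 nM in an assay on isolated protein for inhibition of Indoleamine 2,3-dioxygenase 1 (Homo sapiens), read by spectrophotometry (on this read-out lower numbers stand for stronger inhibition and higher numbers for weaker inhibition), a limit of the assay.
Compound 2: `O/N=C(/Nc1cccc(Oc2ccccc2)c1)c1ccc2occc2c1` gives > 30000 nM in this assay, also a limit.
Compound 3: `O/N=C(/Nc1cccc(Cc2ccccc2)c1)c1ccc2occc2c1` gives > 30000 nM in this assay, again a limit.

For the measured compounds named here, compound 3 stands at the limit of > 30000 nM in this assay, at which 3 of the 3 values shown sit; every value shown is a limit, so no compound can be ordered against another. The step that the two limits leave unreadable from compound 1 to compound 2, the step that the two limits leave unreadable from compound 1 to compound 3 and the step that the two limits leave unreadable from compound 2 to compound 3 are all left unreadable by the two limits, and they give no size to work with.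

Compound 4 is `O/N=C(/Nc1cccc(COc2ccccc2)c1)c1ccc2occc2c1`. It differs from compound 3 by phenoxy in place of phenyl on a saturated chain carbon bound to an aromatic carbon. Going by the values given here, the only steps that bear on it are the unreadable ones above, and none of them shows any compound leaving the limit. Compound 4 is therefore expected to stay at the limit as well, with a step that the limit leaves unreadable from compound 3 to compound 4 that cannot be read against the scatter. The estimate for compound 4 in this assay is 60000 nM, within 20000 nM to 300000 nM.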

Compound 4, half-maximal inhibitory concentration: > 30000 nM
Compound 4 ended at the assay's limit (the forecaster's own chance of this, stated with the estimate: 85%); the middle value lies beyond the limit too.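

No step from compound 1, compound 2 or compound 3 to compound 4 can be read in this assay, because all four compounds sit at the same limit: the limit of > 30000 nM in this assay, at which 4 of the 4 values shown sit.

The compounds shown leave open whether any change on the shared core brings a value inside that limit, and how large such a step would be.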